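Furan-3-yl in Place of Phenyl: Compound 1 to Compound 4

A few compounds are considered here, and "the series" means these few. Any claim that something is new, unique, unknown or untested is made for them only; others in the source may bear on it.

Compound 1 `Cc1nc(N)c2c(-c3ccccc3)cn([C@@H]3O[C@H](CO)[C@@H](O)[C@H]3O)c2n1` in a functional assay on CCRF-CEM cells (Homo sapiens), read by MTT assay, with a stated time of 72 h (a lower number here means a stronger inhibitor, a higher number a weaker inhibitor), gives > 20000 nM, which is a limit of the assay.
Compound 2 `Nc1nc(N)c2c(-c3ccccc3)cn([C@@H]3O[C@H](CO)[C@@H](O)[C@H]3O)c2n1` in this assay gives > 20000 nM, also a limit.
Compound 3 `Nc1nc2c(c(-c3ccco3)cn2[C@@H]2O[C@H](CO)[C@@H](O)[C@H]2O)c(=O)[nH]1` in this assay gives > 20000 nM, again a limit.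

Compound 1 stands only at a limit, so its place among the measured compounds cannot be ranked; all three values share (the limit of > 20000 nM in this assay, at which 3 of the 3 values shown sit). Compound 4 `Cc1nc(N)c2c(-c3ccoc3)cn([C@@H]3O[C@H](CO)[C@@H](O)[C@H]3O)c2n1` differs from compound 1 by furan-3-yl in place of phenyl on an aromatic carbon. Among the compounds with values here, the one measured step, a step that the two limits leave unreadable from compound 1 to compound 2, has a size the two limits leave unreadable, so no measured step gives a size for this change. In this assay compound 4 is therefore expected to remain at the limit, with the step that the limit leaves unreadable from compound 1 to compound 4 expected to stay within the scatter. The estimate for compound 4 is 35000 nM, with a range from 15000 nM to 100000 nM.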

Compound 4, half-maximal inhibitory concentration: > 100000 nM
Compound 4: a limit, no number; the forecaster's own chance of this, stated with the estimate: 85%; middle value at least 2.8-fold (0.45 log units) from the limit.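

Compound 1 and compound 4 each give only a limit in this assay, and the step between them cannot be read. The compounds shown leave open how furan-3-yl in place of phenyl changes potency, with every value in this assay a limit.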